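Thiazolylamide series: thiazolyl in place of methylisoxazolyl

A few compounds are considered here, and "the series" means these few. Any claim that something is new, unique, unknown or untested is made for them only; others in the source may bear on it.

Compound 3 `Cc1cc(NC(=O)Cn2cc(-c3cccc(Cl)c3)nn2)no1` is known in a functional assay on BMDM cells (Mus musculus, strain C57BL/6) for inhibition, with a stated time of 2 days (on this read-out higher numbers stand for weaker inhibition and lower numbers for stronger inhibition), only as a limit: compound 3 reports > 30000 nM, the limit at which it sits (the limit of > 30000 nM in this assay, at which 1 of the 3 values shown sits). The other two members carry the thiazolylamide that compound 4 `O=C(Cn1cc(-c2cccc(Cl)c2)nn1)Nc1nccs1` will also carry. In this assay compound 1 `Nc1cccc(-c2cn(CC(=O)Nc3nccs3)nn2)c1` gives 1270 nM, and compound 2 `O=C(Cn1cc(-c2ccccc2Cl)nn1)Nc1nccs1` gives 60 nM; the step of a 21-fold lower number from compound 1 to compound 2 (1.33 log units; beyond the scatter) concerns the aryl group on the shared core, not the amide side. The change from compound 3 to compound 4 is 1,3-thiazol-2-yl in place of 5-methyl-1,2-oxazol-3-yl on an amide-type nitrogen. Within the data shown here, no measured step covers this exchange on the amide-type nitrogen; what is known is that both thiazolylamides give a number in this assay, whereas compound 3 gives only a limit. On that basis compound 4 is expected to come in below the limit, with the step of an at least 50-fold lower number from compound 3 to compound 4 (1.69 log units; beyond the scatter) estimated as a move into measurable range. Compound 4 is estimated at 600 nM in this assay, within a range of 100 nM to 6000 nM, given that compound 1 with its substituted phenyl gave 1270 nM.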

Compound 4, half-maximal inhibitory concentration: > 30000 nM
Compound 4: a limit, no number; the forecaster's own chance of this, stated with the estimate: 15%; at least 50-fold (1.69 log units) between middle value and limit.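

In this assay compound 4 gives > 30000 nM, a limit and not a number, so the thiazolylamide alone does not secure a measurable value. On the thiazolylamide the aryl group decides the outcome: 3-chlorophenyl in place of 2-chlorophenyl gives an at least 500-fold higher number from compound 2 to compound 4 (2.69 log units; beyond the scatter), and chloro in place of amino on an aromatic carbon gives an at least 23-fold higher number from compound 1 to compound 4 (1.37 log units; beyond the scatter). The exchange of 5-methyl-1,2-oxazol-3-yl for 1,3-thiazol-2-yl on the amide-type nitrogen cannot be read, because compound 3 and compound 4 both stand at a limit: the limit of > 30000 nM in this assay, at which 2 of the 4 values shown sit.

Open, on these data alone, is what the 5-methyl-1,2-oxazol-3-yl amide gives with 2-chlorophenyl on the shared core, a pairing that could make the amide exchange readable. Also open, as far as these compounds go, is how a methoxy group or a carboxylic acid in place of the chloro would read on the thiazolylamide.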